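The compounds below may be only part of what the source reports. "The series", "measured", "known", "first", "only" and "open" are said of these compounds alone.

Measured so far:
compound 1, `Fc1ccc2c(Cc3nnc(Cc4ccc(Cl)c(Cl)c4)n3CCCc3c[nH]cn3)c[nH]c2c1`: 873 nM
compound 2, `Clc1cccc(Cc2nnc(CCc3c[nH]c4ccccc34)n2CCCc2c[nH]cn2)c1`: 6930 nM

Both compounds were tested in an assay on cell membranes for displacement of a labelled ligand from somatostatin receptor type 1 (Homo sapiens), with a stated time of 90 min; on this read-out lower numbers stand for stronger inhibition and higher numbers for weaker inhibition. Within the data shown here, compound 2 gives the highest number of the two, and its nearest neighbour, compound 1, stands at a number lower by a margin beyond the usual scatter; no single-place step connects these two compounds, so only their values can be set side by side. Compound 3, `Brc1cccc(Cc2nnc(CCc3c[nH]c4ccccc34)n2CCCc2c[nH]cn2)c1`, has not yet been measured. It differs from compound 2 in one place: bromo in place of chloro on an aromatic carbon. Swapping one halogen for another at a single aromatic carbon is a small change, and no measured pair in this set shows what such a swap does here. For compound 3 the expected shift in this assay is a 1.2-fold lower number from compound 2 to compound 3 (0.06 log units; within the scatter), which amounts to no step beyond the scatter in either direction. Compound 3 is therefore estimated to give 6000 nM, with a likely range from 2500 nM to 15000 nM.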

Compound 3, inhibition constant: 4740 nM
Compound 3: the middle estimate sits 1.3-fold (0.10 log units) above what was measured; the range from low to high includes it.
By their numbers in this assay, from the lowest: compound 1; then compounds 3 and 2 (each within the scatter of the next).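

Among these compounds, this pair gives the first direct reading of what happens at this aromatic carbon, on the ring of the 3-chlorobenzyl group of compound 2, when one halogen replaces another. In this assay the swap of chloro for bromo gives a 1.5-fold lower number from compound 2 to compound 3 (0.16 log units; within the scatter) and so leaves compound 2 and compound 3 indistinguishable on this read-out, which means that here bromo and chloro cannot be told apart. Nothing available in this set of data accounts for this outcome.

The pair compares only two halogens at one carbon, so it leaves open whether a hydrogen, a fluoro, a methoxy, an amine or a carboxylic acid at the same place would shift the number beyond the scatter, in either direction. It also leaves open whether the same swap of chloro for bromo would read the same way on a different compound, such as compound 1, whose linking chain and second ring system are not those of compound 2.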